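Aryl substituent change from bromo to methyl in compound 4

The source may hold more compounds than are shown below. What is called first, only, known or untested is meant among the compounds shown, and "the series" means these compounds.

Compound 2 `O=C(CSc1nnnn1-c1ccccc1)N/N=c1/scc(-c2ccc(Br)cc2)n1-c1ccccc1` gives 61.8% in a functional assay on C6 cells (Rattus norvegicus) for cytotoxicity, read by MTT assay, with a stated time of 24 h, tested at 6 ug/mL (on this read-out lower numbers stand for a stronger effect and higher numbers for a weaker effect at the one concentration tested), the lowest of the three numbers measured. Compound 1 `Cc1nnc(SCC(=O)N/N=c2/scc(-c3ccccc3)n2-c2ccccc2)s1` gives 72.4% and compound 3 `Cc1nnc(SCC(=O)N/N=c2/scc(-c3ccc(Cl)cc3)n2-c2ccccc2)s1` gives 82.8%; both steps from compound 2 lie beyond the scatter. For the measured compounds named here, the only single-point step in hand, a number 10.4 percentage points higher from compound 1 to compound 3 (beyond the scatter), concerns the same six-membered aromatic ring of carbon only. Compound 4 `Cc1ccc(-c2cs/c(=N/NC(=O)CSc3nnnn3-c3ccccc3)n2-c2ccccc2)cc1` differs from compound 2 by methyl in place of bromo on an aromatic carbon, placed para to a large group. Going by the values given here, no measured step exchanges bromo for methyl, so the direction is open; the chloro step was modest, and a step of comparable size in either direction is expected. Compound 4 is estimated at 69%, range 56% to 82%, so that a number 7.2 percentage points higher from compound 2 to compound 4 (within the scatter) is expected.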

Compound 4, a percentage reported as activity, at one concentration (the size of the read-out at that concentration, not a potency): 66.8%
Estimate against measurement, compound 4: 2.2 percentage points above, and the stated range covers the measured number.
By their numbers in this assay, from the lowest: compounds 2, 4 and 1 (each within the scatter of the next, the first and the last beyond it); then compound 3.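

In this assay, the exchange of 4-bromophenyl for 4-methylphenyl gives a number 5 percentage points higher from compound 2 to compound 4 (within the scatter), so this read-out does not separate methyl from bromo at this place. The earlier step at this place, a number 10.4 percentage points higher from compound 1 to compound 3 (beyond the scatter), was chloro in place of hydrogen, and it lies beyond the scatter. No evidence at hand bears on the reason for this result. As far as these compounds go, whether an amine or a carboxylic acid here would move the number beyond the scatter remains open. So does whether methyl in place of bromo reads alike on the core of compound 1.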